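Swapping a pyridine for a pyrimidine on the piperazine

The compounds below may be only part of what the source reports. "The series", "measured", "known", "first", "only" and "open" are said of these compounds alone.

Of the compounds shown here, two have been measured in an assay on CHO cells for displacement of a labelled ligand from adenosine receptor A1 (Homo sapiens); on this read-out higher numbers stand for weaker binding and lower numbers for tighter binding. Compound 1 `N#Cc1ccc(N2CCN(Cc3csc(N)c3C(=O)c3ccc(Cl)cc3)CC2)cc1` gives 1.1 nM. Compound 2 `Nc1scc(CN2CCN(c3ccccn3)CC2)c1C(=O)c1ccc(Cl)cc1` gives 1.2 nM. Going by the values given here, the only measured step, a 1.1-fold higher number from compound 1 to compound 2 (0.04 log units; within the scatter), shows that exchanging one aromatic group for another on the ring amine nitrogen left the number essentially unchanged. Compound 2 therefore holds the higher of the two numbers, but the gap to compound 1 is within the scatter, so the two cannot be told apart.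

The next compound, compound 3 `Nc1scc(CN2CCN(c3ncccn3)CC2)c1C(=O)c1ccc(Cl)cc1`, keeps the whole core of compound 2 and differs only in one place: pyrimidin-2-yl in place of pyridin-2-yl on an amine nitrogen in a ring. Among the compounds with values here, no measured step covers this exact exchange. Within the data shown here, the one step that bears on it is a 1.1-fold higher number from compound 1 to compound 2 (0.04 log units; within the scatter), which changed the same aromatic group at the same nitrogen and produced no movement beyond the scatter. On that basis, the step from compound 2 to compound 3 is expected to be small, with no clear direction. This estimate means an expected 1.3-fold higher number from compound 2 to compound 3 (0.10 log units; within the scatter). Compound 3 is therefore expected to give 1.5 nM, most likely between 0.6 nM and 4 nM.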

Compound 3, dissociation constant: 1.1 nM
The estimate for compound 3 lay 1.4-fold (0.13 log units) above the measured number; the measured number falls inside the stated range.
By their numbers in this assay, from the lowest: compounds 1, 3 and 2 (each within the scatter of the next).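

In this assay, putting pyrimidin-2-yl in place of pyridin-2-yl gives a 1.1-fold lower number from compound 2 to compound 3 (0.04 log units; within the scatter) and putting it in place of 4-cyanophenyl gives no change at the digits printed from compound 1 to compound 3 (within the scatter) so a third aromatic group on this ring nitrogen also cannot be told apart from the others. What is new is the nature of the exchange: pyrimidin-2-yl has 2 hetero atoms in its ring and 2 hydrogen-bond acceptors where pyridin-2-yl has 1 of each, yet across compounds 1, 2 and 3 these counts do not separate the numbers, and this position accepts all three six-membered aromatic rings without a difference beyond the scatter. Nothing available explains why the three numbers lie so close together.

Going by these compounds, all three compounds carry a six-membered aromatic ring at this nitrogen, so it remains open whether the same holds for a group without one, such as a cyclohexyl ring or a plain methyl. On these data alone, it also remains open how a further substituent on the pyrimidine ring, such as a methoxy group or an amine, would affect the number.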